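From Methoxy to Isopropyl: An Expected Step

A few compounds are considered here, and "the series" means these few. Any claim that something is new, unique, unknown or untested is made for them only; others in the source may bear on it.

Compounds measured in a physicochemical assay for lipophilicity, read by HPLC, at pH 7.5 (a lower number here means a more polar compound, a higher number a more lipophilic compound), so far
- compound 1 (`CCOc1ccccc1-c1ccc(-c2nc3cnccc3c(N[C@H](CC)C(N)=O)c2C#N)cc1`) gives 3
- compound 2 (`CC[C@@H](Nc1c(C#N)c(-c2ccc(-c3ccccc3OC)cc2)nc2cnccc12)C(N)=O`) gives 2.7

Compound 2 stands at 2.7 and lies within the usual scatter of compound 1 in this assay on these two numbers. Compound 3 (`CC[C@@H](Nc1c(C#N)c(-c2ccc(-c3ccccc3C(C)C)cc2)nc2cnccc12)C(N)=O`) has isopropyl in place of methoxy on an aromatic carbon, ortho to a large group, so that 2-methoxyphenyl becomes 2-isopropylphenyl isopropyl in place of methoxy on an aromatic carbon in an otherwise unchanged structure. For the measured compounds named here, the only measured step that touches this group is a number 0.30 log units lower from compound 1 to compound 2 (within the scatter) and it stays within the scatter. Going by the values given here, that step keeps the oxygen, and no measured step removes it, so the data set no size for this change. Measured against the step of a number 0.30 log units lower from compound 1 to compound 2 (within the scatter) the change in compound 3 is the larger structural one, and a higher number is expected. The expected size is a number 0.80 log units higher from compound 2 to compound 3 (beyond the scatter) on the structural change alone. Compound 3 is estimated at 3.5 with a range from 3 to 4 on this reading.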

Compound 3, distribution coefficient: 3.5
Compound 3: the middle estimate sits on the measured number at the digits printed; the measured number falls inside the stated range.
By their numbers in this assay, from the lowest: compounds 2 and 1 (each within the scatter of the next); then compound 3.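

For the compounds shown here, at this position, on an aromatic carbon ortho to a large group, compound 3 gives the first steps in this assay that lie beyond the scatter (a number 0.80 log units higher from compound 2 to compound 3 (beyond the scatter)) and (a number 0.50 log units higher from compound 1 to compound 3 (beyond the scatter)). Whether the group is methoxy or ethoxy, replacing it with isopropyl therefore gives a separable change, whereas changing only the chain on the oxygen did not. Nothing measured here explains the size of these steps.

Isopropyl differs from methoxy both in losing the oxygen and in its carbon count, and these compounds cannot separate the two differences. They also leave open where a plain methyl, a tert-butyl or an amine in this place would fall in this assay relative to compound 3.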